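Fluoro on the benzyl ring of compound 1

The compounds below may be only part of what the source reports. "The series", "measured", "known", "first", "only" and "open" are said of these compounds alone.

Compound 1 `O=c1c2ccccc2[se]n1-c1nc(SCc2ccccc2)n[nH]1` carries a benzyl group on the sulfur of the shared core. In an ADME assay on L929 cells (Mus musculus) for antiproliferative activity, read by CCK-8 assay, with a stated time of 48 h (on this read-out lower numbers stand for stronger inhibition and higher numbers for weaker inhibition), compound 1 gives only a limit, > 50000 nM. That is the limit of > 50000 nM in this assay, at which 1 of the 3 values shown sits. Its two measured neighbours both swap the phenyl for a small alkyl: compound 2 `CCSc1n[nH]c(-n2[se]c3ccccc3c2=O)n1` gives 35200 nM and compound 3 `CC(C)CSc1n[nH]c(-n2[se]c3ccccc3c2=O)n1` gives 33400 nM. The steps are an at least 1.4-fold lower number from compound 1 to compound 2 (0.15 log units; that floor lies within the scatter) and an at least 1.4-fold lower number from compound 1 to compound 3 (0.17 log units; that floor lies within the scatter), while between the two alkyls there is a 1.1-fold lower number from compound 2 to compound 3 (0.02 log units; within the scatter).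

Compound 4 `O=c1c2ccccc2[se]n1-c1nc(SCc2ccc(F)cc2)n[nH]1` keeps the benzyl and differs from compound 1 by fluoro in place of hydrogen on an aromatic carbon. Among the compounds with values here, no measured step touches the benzyl ring itself; the only steps on hand remove the phenyl altogether, and even those reach no farther than floors that lie within the scatter. A single fluoro on the ring is a smaller structural change than any of them, so no step beyond the scatter in this assay is expected in either direction, and compound 4 is expected to sit at or close to the limit again. Compound 4 is estimated at 50000 nM, with a range from 25000 nM to 100000 nM. The expected step is thus a number no higher from compound 1 to compound 4 (the limit leaves the size open), most likely reported only as a limit.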

Compound 4, half-maximal inhibitory concentration: > 50000 nM
Compound 4 was reported as a limit; the forecaster's own chance of this, stated with the estimate: 70%; the middle value lies on the limit itself.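

Compound 4 gives > 50000 nM in this assay and, like the value of compound 1, this is a limit and not a number. With both ends of the change at limits, the step for fluoro in place of hydrogen on the aromatic carbon cannot be read, so this position gives no readable effect of the fluoro in either direction. Against the alkyl compounds, an at least 1.4-fold higher number from compound 3 to compound 4 (0.17 log units; that floor lies within the scatter) and an at least 1.4-fold higher number from compound 2 to compound 4 (0.15 log units; that floor lies within the scatter) are the only readable steps, and they add no step beyond the scatter, while the benzyl and 4-fluorobenzyl compounds now share the same ceiling: the limit of > 50000 nM in this assay, at which 2 of the 4 values shown sit.

From the compounds shown here alone, whether any change on the benzyl ring can bring the number down to a readable value stays open, and an amine or a carboxylic acid on that ring would test this more sharply than a single fluoro. Also open, going by these compounds, is whether a longer chain on the sulfur would give a step beyond the scatter from compound 2 and compound 3.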